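The source may report more compounds than this note shows. Statements on the series, on what has been measured and on what is new or still open speak of the compounds shown alone.

Measured compounds:
compound 1 `CN1CCN(c2ccc(Nc3ncc4nc(Nc5ccc(F)cc5)n([C@H]5CCCN(S(=O)(=O)C6CC6)C5)c4n3)cc2)CC1`, giving 1340 nM in a functional assay on A-431 cells (Homo sapiens) for antiproliferative activity, read by MTT assay, with a stated time of 72 h; on this read-out higher numbers stand for weaker inhibition and lower numbers for stronger inhibition
compound 2 `CN1CCN(c2ccc(Nc3ncc4nc(Nc5ccc(F)cc5)n([C@@H]5CCCNC5)c4n3)cc2)CC1`, for which this assay gives only "not determined" (no result reported), no result

Among the measured compounds shown here, compound 2 therefore has no number to stand on; the only value available is that of compound 1 in this assay, 1340 nM, and with nothing measured for compound 2, no step from compound 2 to compound 1 can be stated. The step from compound 2 to compound 3 `CN1CCN(c2ccc(Nc3ncc4nc(Nc5ccc(F)cc5)n([C@H]5CCN(S(=O)(=O)C6CC6)C5)c4n3)cc2)CC1` consists of 1-(cyclopropylsulfonyl)pyrrolidin-3-yl in place of piperidin-3-yl on an aromatic nitrogen. Compound 3 thus carries the same cyclopropylsulfonyl group as compound 1, now on a five-membered ring instead of a six-membered one. With no comparison of measured values to lean on, the size and direction of the step from compound 2 to compound 3 in this assay cannot be stated; the expectation for compound 3 rests on compound 1 alone. Compound 3 is estimated to give about 1500 nM in this assay, expected to lie between 400 nM and 6000 nM.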

Compound 3, half-maximal inhibitory concentration: 1670 nM
For compound 3 the middle estimate is 1.1-fold (0.05 log units) below the measured one; measured number inside the range.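

In this assay, among the compounds shown here, the step from the six-membered to the five-membered ring bearing the cyclopropylsulfonyl group is a 1.2-fold higher number from compound 1 to compound 3 (0.10 log units; within the scatter) and is the first step at this aromatic nitrogen that can be read. The change of 1-(cyclopropylsulfonyl)piperidin-3-yl to 1-(cyclopropylsulfonyl)pyrrolidin-3-yl therefore does not separate these two compounds on this read-out, and this holds only for this pair. No measured evidence bears on this result.

From the compounds shown here alone, the contribution of the cyclopropylsulfonyl group itself stays open, as the piperidin-3-yl of compound 2 offers no number for comparison. Also open, going by these compounds, is whether a methylsulfonyl or an acetyl group on the ring nitrogen, or an azetidine ring in place of the pyrrolidine, would read any differently.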